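The compounds below may be only part of what the source reports. "The series", "measured", "known", "first", "only" and "open" are said of these compounds alone.

Measured compounds:
Compound 1, `CC(C)=CCn1c(CN2CCN(C(=O)C3CC3)CC2)nc2ccccc21`, 74.3% in an assay on isolated protein for inhibition of aldehyde dehydrogenase 1A1 (Homo sapiens), read by spectrophotometry, tested at 10 uM; a higher number here means more inhibition at the concentration tested (going by the name of the read-out), a lower number less inhibition.
Compound 2, `CCC(=O)N1CCN(Cc2nc3ccccc3n2Cc2cccc(C)c2)CC1`, 85.1% in this assay.

Of these two numbers compound 1 has the lower one; compound 2 lies higher by a gap beyond the usual scatter. Compound 3, `O=C(C1CC1)N1CCN(Cc2nc3ccccc3n2Cc2cccc(Cl)c2)CC1`, is not yet measured in this assay. It differs from compound 1 by 3-chlorophenyl in place of 2-methylprop-1-en-1-yl on a saturated chain carbon bound to an aromatic nitrogen, a change that makes the shared core carry a benzyl group as compound 2 does. Among the compounds with values here, no step between measured compounds covers this change. Compound 3 is expected to show an estimated step of a number 7.7 percentage points higher from compound 1 to compound 3 (within the scatter), upward but modest, resting on the higher reading of compound 2 at 85.1%. For compound 3 the estimated inhibition is 82%, in the range 66% to 94%.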

Compound 3, a percentage reported as inhibition, at one concentration (the size of the read-out at that concentration, not a potency): 71.6%
The estimate for compound 3 lay 10.4 percentage points above the measured number, within the range that was stated.
By their numbers in this assay, from the lowest: compounds 3 and 1 (each within the scatter of the next); then compound 2.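

In this assay, putting 3-chlorobenzyl in place of 3-methylbut-2-en-1-yl gives a number 2.7 percentage points lower from compound 1 to compound 3 (within the scatter) and so separates the two groups by no readable difference. On a saturated chain carbon bound to an aromatic nitrogen, the aromatic ring with its chlorine thus reads the same as the open chain with its double bond. Nothing at hand accounts for this reading.

Open, from the compounds shown here alone, is how plain benzyl or 3-methylbenzyl would read with the rest of compound 3 unchanged. Also open, going by these compounds, is how a chain carrying an amine or a carboxylic acid would read at this place.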